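Glycinamide linker series: compound 3 from compound 2

The compounds below may be only part of what the source reports. "The series", "measured", "known", "first", "only" and "open" are said of these compounds alone.

Compound 2 `CC(C)NCC(=O)NCC(=O)N(C)c1ccc(Cl)cc1C(=O)c1ccccc1Cl` gives the lowest number of the two measured in a functional assay on the whole organism for antagonist activity, with Mus musculus as the target (on this read-out lower numbers stand for an effect already at smaller amounts and higher numbers for an effect only at larger amounts of compound), at 1 mg/kg; compound 1 `CN(C(=O)CNC(=O)CN1CCCCC1)c1ccc(Cl)cc1C(=O)c1ccccc1Cl` gives 7.5 mg/kg, a step of a 7.5-fold lower number from compound 1 to compound 2 (0.88 log units; beyond the scatter). Compound 3 `CC(NC(=O)CN)C(=O)N(C)c1ccc(Cl)cc1C(=O)c1ccccc1Cl` differs from compound 2 by 1-(((aminomethyl)carbonyl)amino)ethyl in place of ((((isopropylamino)methyl)carbonyl)amino)methyl on a carbonyl carbon. Going by the values given here, the only measured step alters the terminal amine, as this change does, but here the amine loses its alkyl group while a methyl enters on the chain, so it is not a direct guide. A small step is expected, a 2.0-fold higher number from compound 2 to compound 3 (0.30 log units; within the scatter), towards a higher number. Compound 3 is estimated at 2 mg/kg, within 0.7 mg/kg to 6 mg/kg.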

Compound 3, dose for half-maximal effect: 0.47 mg/kg
Compound 3: the middle estimate sits 4.3-fold (0.63 log units) above what was measured; measured number outside the range, below it.
By their numbers in this assay, from the lowest: compound 3; then compound 2; then compound 1.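

In this assay, 1-(((aminomethyl)carbonyl)amino)ethyl in place of ((((isopropylamino)methyl)carbonyl)amino)methyl on a carbonyl carbon gives a 2.1-fold lower number from compound 2 to compound 3 (0.33 log units; beyond the scatter) and so extends the series to a lower number. At this position, the low numbers therefore do not depend on the isopropyl group on the amine, and a methyl on the chain is tolerated. No available evidence bears on the reason for this step.

The step combines both changes, so their separate contributions remain unresolved. The primary amine on the unbranched chain and isopropylamino on the methyl-bearing chain would separate them.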